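Benzylidene indanones against Jurkat cell growth

The compounds below may be only part of what the source reports. "The series", "measured", "known", "first", "only" and "open" are said of these compounds alone.

Measured compounds:
compound 1 `COc1cc2c(cc1OC)C(=O)/C(=C/c1cccc([N+](=O)[O-])c1)C2`: 22000 nM
compound 2 `COc1cc2c(cc1OC)C(=O)/C(=C/c1cc([N+](=O)[O-])ccc1O)C2`: 14500 nM
compound 3 `COc1cc2c(cc1O)C/C(=C\c1cc(C)c(O)c(C)c1)C2=O`: 530 nM

Three benzylidene indanones have been examined in a functional assay on Jurkat cells (Homo sapiens) for antiproliferative activity, read by MTT assay; a lower number here means a stronger inhibitor, a higher number a weaker inhibitor. Compound 1 `COc1cc2c(cc1OC)C(=O)/C(=C/c1cccc([N+](=O)[O-])c1)C2` gives 22000 nM, and compound 2 `COc1cc2c(cc1OC)C(=O)/C(=C/c1cc([N+](=O)[O-])ccc1O)C2` gives 14500 nM. The two differ in one place, (hydrogen in place of hydroxy on an aromatic carbon), and the step of a 1.5-fold higher number from compound 2 to compound 1 (0.18 log units; within the scatter) is small. Compound 3 `COc1cc2c(cc1O)C/C(=C\c1cc(C)c(O)c(C)c1)C2=O` gives 530 nM, the lowest of the three, standing well apart from both others. Compound 3 and compound 2 differ in more than one place, and the difference between the two cores is not broken down here.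

Compound 4 `COc1ccc2c(c1)C(=O)/C(=C/c1cc(C)c(O)c(C)c1)C2` has not yet been measured in this assay. It differs from compound 3 by hydrogen in place of hydroxy on an aromatic carbon. This is the same kind of change as that from compound 2 to compound 1, but at a different place: there the hydroxy sat ortho to a large group and para to a nitro group on the benzylidene ring, whereas here it sits on the fused ring of the core, ortho to a methoxy group, meta and para to the fused ring. Among the measured compounds shown here, the one measured example of this kind of change, a 1.5-fold higher number from compound 2 to compound 1 (0.18 log units; within the scatter), lay within the scatter, which gives some ground to expect a modest step from compound 3 to compound 4 as well, though the different surroundings leave room for a larger shift. The step expected is a 1.7-fold higher number from compound 3 to compound 4 (0.23 log units; within the scatter). Compound 4 is therefore estimated at 900 nM, with a range from 300 nM to 3000 nM.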

Compound 4, half-maximal inhibitory concentration: > 50000 nM
Compound 4: no number, only a limit (the forecaster's own chance of this, stated with the estimate: 5%); middle value at least 55-fold (1.74 log units) away from the limit.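

Compound 4 reads > 50000 nM in this assay, which is a limit of the assay and not a number. Losing the hydroxy from the fused ring of compound 3 gives an at least 94-fold higher number from compound 3 to compound 4 (1.97 log units; beyond the scatter), while the same exchange on the benzylidene ring gave a 1.5-fold higher number from compound 2 to compound 1 (0.18 log units; within the scatter), so the two steps disagree: the same change on two cores in this assay, a 1.5-fold higher number (0.18 log units; within the scatter) from compound 2 to compound 1 and an at least 94-fold higher number (1.97 log units; beyond the scatter) from compound 3 to compound 4, at least 62-fold (1.79 log units) apart, beyond the scatter of two such steps This shows that the small step seen in the first pair does not carry over to the second pair and that, in this series, the effect of exchanging a hydroxy for hydrogen cannot be read from one core to another; it does not show why, since the two pairs differ both in where the hydroxy sits and in the rest of the structure, and the limit leaves the full size of the new step unknown.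

The compounds shown leave open whether the hydroxy itself is needed at its place ortho to a methoxy group, or whether an amine or a fluorine there would keep the activity of compound 3. They also leave open what the same exchange would do to the hydroxy on the benzylidene ring of compound 3.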